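Methoxy on the Pendant Phenyl: Notes Toward Compound 3

The source may hold more compounds than are shown below. What is called first, only, known or untested is meant among the compounds shown, and "the series" means these compounds.

Compound 1 `COc1cc(OC)c(C2CC(=O)c3cc(OC)c(OC)c(OC)c32)c(OC)c1` carries a trimethoxyphenyl on the shared core, and in a functional assay on MCF7 cells (Homo sapiens) for cytotoxicity, read by MTT assay, with a stated time of 24 h (on this read-out lower numbers stand for stronger inhibition and higher numbers for weaker inhibition), compound 1 gives 211000 nM. Compound 2 `COc1cc2c(c(OC)c1OC)C(c1ccccc1)CC2=O` carries a plain phenyl in its place. In this assay compound 2 reaches only a limit of the assay, >= 250000 nM, so no number is known for it. Compound 2 therefore stands at the limit of >= 250000 nM in this assay, at which 1 of the 2 values shown sits, the weaker end of what has been seen in this series.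

Compound 3 `COc1cccc(C2CC(=O)c3cc(OC)c(OC)c(OC)c32)c1` is compound 2 with methoxy in place of hydrogen on an aromatic carbon. Among the measured compounds shown here, no measured pair differing in one place is available to size such a change, and the two values of compounds 1 and 2 show only that one gives a number and the other a limit.

The step from compound 2 to compound 3 in this assay is expected to be an at least 1.1-fold lower number from compound 2 to compound 3 (0.05 log units; that floor lies within the scatter), not beyond the scatter. Compound 3 is estimated at 220000 nM, with a range from 110000 nM to 400000 nM, and a fair chance that this assay again reports only a limit.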

Compound 3, half-maximal inhibitory concentration: >= 250000 nM
Compound 3 gave a limit, no number (the forecaster's own chance of this, stated with the estimate: 50%); middle value at least 1.1-fold (0.05 log units) away from the limit.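

In this assay compound 3 gives only a limit, >= 250000 nM, and compound 2 also gives only a limit, so no step can be read between compound 2 and compound 3. On these data alone, the size of any effect of 3-methoxyphenyl in place of phenyl remains open.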